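The compounds below may be only part of what the source reports. "The series", "measured", "known", "first", "only" and "open" are said of these compounds alone.

Compound 1 `COc1cc(C(=O)C2Sc3nnc(-c4cc(OC)c(OC)c(OC)c4)n3NC2c2ccco2)cc(OC)c1OC` opens the series and is followed in a functional assay on MCF7 cells (Homo sapiens) for cytotoxicity, read by MTT assay, with a stated time of 48 h; on this read-out higher numbers stand for weaker inhibition and lower numbers for stronger inhibition. In this assay compound 1 sits at a limit and not a number, > 100000 nM. That limit is the ceiling described as the limit of > 100000 nM in this assay, at which 2 of the 3 values shown sit. Compound 2 `COc1cc(-c2nnc3n2NC(c2ccco2)C(C(=O)c2ccccc2)S3)cc(OC)c1OC` gives in this assay a readable value, 39800 nM. Among the measured compounds shown here, the step of an at least 2.5-fold lower number from compound 1 to compound 2 (0.40 log units; beyond the scatter) is the one change on the carbonyl carbon that yields a number. Compound 3 `COc1cc(-c2nnc3n2NC(c2ccco2)C(C(=O)c2ccc(-c4ccccc4)cc2)S3)cc(OC)c1OC` again returns a limit in this assay, > 100000 nM. The step that the two limits leave unreadable from compound 1 to compound 3 therefore cannot be sized, whereas an at least 2.5-fold higher number from compound 2 to compound 3 (0.40 log units; beyond the scatter) runs upward.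

Compound 4 `COc1cccc(C(=O)C2Sc3nnc(-c4cc(OC)c(OC)c(OC)c4)n3NC2c2ccco2)c1` carries the change (3-methoxyphenyl in place of 3,4,5-trimethoxyphenyl on a carbonyl carbon). The step that bears on it is an at least 2.5-fold lower number from compound 1 to compound 2 (0.40 log units; beyond the scatter), in which stripping the aryl on the carbonyl carbon of all three methoxy groups lowered the number past the scatter. Compound 4 keeps one methoxy on that aryl, so an expected downward step smaller than that one, or at its edge, is set here as an at least 2.0-fold lower number from compound 1 to compound 4 (0.30 log units; that floor lies within the scatter). Compound 4 is accordingly estimated at 50000 nM in this assay, between 15000 nM and 150000 nM, with a real chance that the read-out again stops at a limit.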

Compound 4, half-maximal inhibitory concentration: > 100000 nM
Compound 4 was reported as a limit; the forecaster's own chance of this, stated with the estimate: 40%; middle value at least 2.0-fold (0.30 log units) from the limit.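

Adding a single methoxy to the unsubstituted phenyl on the carbonyl carbon is enough to lose the readable value in this assay, with an at least 2.5-fold higher number from compound 2 to compound 4 (0.40 log units; beyond the scatter). The full 3,4,5-trimethoxyphenyl is therefore not needed to return to the ceiling, since 3-methoxyphenyl on this carbonyl carbon ends at the same limit as 3,4,5-trimethoxyphenyl and 4-phenylphenyl, which leaves the unsubstituted phenyl as the only aryl here that gives a number: the limit of > 100000 nM in this assay, at which 3 of the 4 values shown sit. The steps among the three compounds at that limit cannot be read, so nothing separates 3-methoxyphenyl from the other two aryl groups.

As far as these compounds go, how far these three compounds lie beyond the ceiling stays unknown, and so does whether any of them differ from one another at all. Also open, from the compounds shown here alone, is whether a fluorine, a hydroxyl, an amine or a carboxylic acid in place of hydrogen on that phenyl would keep a readable value or improve on compound 2 at 39800 nM.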